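Permeability notes on the hydroxy-acyl series

The source may hold more compounds than are shown below. What is called first, only, known or untested is meant among the compounds shown, and "the series" means these compounds.

Measured so far in an ADME assay on Caco-2 cells (Homo sapiens) for permeability, read by LC-MS, in the apical to basolateral direction, with a stated time of 60 min, at pH 6.5; a lower number here means that the compound crosses the layer more slowly, a higher number that the compound crosses the layer faster:
compound 1 `O=C(NCc1cc(Cl)ccc1-n1cnnn1)[C@@H]1[C@@H]2C[C@@H]2CN1C(=O)[C@H](O)c1ccccc1` gives 2.2 10^-6 cm/s
compound 2 `CC(C)(C)C[C@@H](O)C(=O)N1NCC[C@H]1C(=O)NCc1cc(Cl)ccc1-n1cnnn1` gives 15 10^-6 cm/s
compound 3 `O=C(NCc1cc(Cl)ccc1-n1cnnn1)[C@@H]1CCNN1C(=O)[C@H](O)c1ccccc1` gives 5.3 10^-6 cm/s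

Compound 3 stands second highest of the three numbers in this assay: compound 1 lies below it, compound 2 above it, and both gaps are beyond the scatter.

The next member is compound 4 `CC(C)(C)[C@@H](O)C(=O)N1NCC[C@H]1C(=O)NCc1cc(Cl)ccc1-n1cnnn1`. Its difference from compound 3 is tert-butyl in place of phenyl on a saturated chain carbon bound to a carbonyl carbon and an oxygen on a saturated carbon.

Going by the values given here, one measured step bears on this. The step of a 2.8-fold lower number from compound 2 to compound 3 (0.45 log units; beyond the scatter) replaced an alkyl group on the same saturated chain carbon with phenyl and gave a modest fall. Compound 4 reverses that direction, putting an alkyl group back in place of the phenyl, though tert-butyl rather than neopentyl. Compound 3 to compound 4 is therefore expected to rise in this assay, by a step that is estimated as a 1.9-fold higher number from compound 3 to compound 4 (0.28 log units; within the scatter), most likely somewhat short of the full return to the number of compound 2, given the shorter alkyl group. Among the compounds with values here, only a single step supports this expectation, so the range is kept wide.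

For compound 4 the estimate in this assay is 10 10^-6 cm/s, with a range from 5 10^-6 cm/s to 20 10^-6 cm/s.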

Compound 4, apparent permeability: 7.2 10^-6 cm/s
The estimate for compound 4 lay 1.4-fold (0.14 log units) above the measured number; low and high end bracket the measured number.
By their numbers in this assay, from the lowest: compound 1; then compounds 3 and 4 (each within the scatter of the next); then compound 2.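

In this assay, tert-butyl and phenyl on the saturated chain carbon bound to a carbonyl carbon and an oxygen on a saturated carbon are not told apart: a 1.4-fold higher number from compound 3 to compound 4 (0.13 log units; within the scatter), so a group with no ring and a six-membered aromatic ring of carbon give numbers within the scatter of each other. Neopentyl stands apart from both, with a 2.1-fold lower number from compound 2 to compound 4 (0.32 log units; beyond the scatter) alongside the earlier 2.8-fold lower number from compound 2 to compound 3 (0.45 log units; beyond the scatter), which shows that putting an alkyl group in place of phenyl does not by itself return the series to the number of compound 2. No measurement at hand gives a reason for these numbers.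

What the compounds shown leave open is whether the separate standing of neopentyl extends to a longer chain on this carbon, such as a hexyl group, or is particular to neopentyl itself. Also open are how an amine or a carboxylic acid at this position would read, and whether tert-butyl and phenyl would stay this close on the core of compound 1, which is shown here with phenyl only.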